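Methoxy for methyl on the benzoyl ring of compound 3

A few compounds are considered here, and "the series" means these few. Any claim that something is new, unique, unknown or untested is made for them only; others in the source may bear on it.

Measured so far in a functional assay on MCF7 cells (Homo sapiens) for cytotoxicity, read by MTT assay, with a stated time of 48 h; a lower number here means a stronger inhibitor, a higher number a weaker inhibitor:
compound 1, `COc1cc(-c2nnc3n2NC(c2ccco2)C(C(=O)c2ccc(F)cc2)S3)cc(OC)c1OC`, > 100000 nM
compound 2, `COc1ccc(C(=O)C2Sc3nnc(-c4cc(OC)c(OC)c(OC)c4)n3NC2c2cccs2)cc1`, 49500 nM
compound 3, `COc1cc(-c2nnc3n2NC(c2ccco2)C(C(=O)c2ccc(C)cc2)S3)cc(OC)c1OC`, > 100000 nM

The value of compound 1 in this assay is a limit, not a number. The value of compound 3 is likewise a limit. Compound 2 gives a number, and it carries the thiophene rather than the furan. The step that the two limits leave unreadable from compound 1 to compound 3 cannot be sized, since both ends sit at the limit (the limit of > 100000 nM in this assay, at which 2 of the 3 values shown sit).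

Compound 4, `COc1ccc(C(=O)C2Sc3nnc(-c4cc(OC)c(OC)c(OC)c4)n3NC2c2ccco2)cc1`, differs from compound 3 by methoxy in place of methyl on an aromatic carbon, on an aromatic carbon of a six-membered aromatic ring of carbon only, para to a large group. Within the data shown here, no measured step bears on this change directly; the only guide is that compound 2, which carries the same (4-methoxyphenyl)carbonyl, gives 49500 nM. Compound 4 is therefore expected near the limit, with a step of an at least 1.2-fold lower number from compound 3 to compound 4 (0.09 log units; that floor lies within the scatter) that cannot be called beyond the scatter. The estimate for compound 4 is 80000 nM, between 30000 nM and 200000 nM.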

Compound 4, half-maximal inhibitory concentration: > 100000 nM
Compound 4 gave a limit, no number; the forecaster's own chance of this, stated with the estimate: 55%; middle value at least 1.2-fold (0.09 log units) away from the limit.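

Putting the (4-methoxyphenyl)carbonyl on the furan-2-yl compound does not by itself bring a measurable number in this assay, so that group alone does not give compound 2 its measured value. Among these compounds, the one readable comparison, for furan-2-yl in place of thiophen-2-yl, is an at least 2.0-fold higher number from compound 2 to compound 4 (0.30 log units; that floor lies within the scatter); only a floor is given, so the real gap could be larger. The steps from compound 1 and compound 3 to compound 4 cannot be read, and most of the series now sits at one limit: the limit of > 100000 nM in this assay, at which 3 of the 4 values shown sit.

As far as these compounds go, whether methoxy, methyl and fluoro differ at all at this place on the ring remains open among the furan-2-yl compounds, as does whether methyl or fluoro would give a number alongside thiophen-2-yl. From the compounds shown here alone, what an amine or a carboxylic acid would do at this place is also open.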